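Extending the Ester Chain of Compound 2

This account rests on a few compounds, and the source may have more. Where it says the series, first, only, none or still open, it means among the compounds named here.

Two esters sharing one core have been measured in an ADME assay on Vero cells (Chlorocebus sabaeus) for cytotoxicity, read by reporter gene assay, with a stated time of 4 days; a higher number here means a weaker inhibitor, a lower number a stronger inhibitor. Compound 1 `CCCC(C)C(=O)OCC(C)(C)CC1=C(O)C(=O)c2ccccc2C1=O` gives 120 nM in this assay, and compound 2 `CCCCCCCCC(=O)OCC(C)(C)CC1=C(O)C(=O)c2ccccc2C1=O` gives 150000 nM. Compound 2 therefore stands at the higher of the two numbers, separated from compound 1 by a 1300-fold higher number from compound 1 to compound 2 (3.10 log units; beyond the scatter), a step in which octyl replaces 1-methylbutyl on a carbonyl carbon.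

The next compound, compound 3 `CCCCCCCCCCCC(=O)OCC(C)(C)CC1=C(O)C(=O)c2ccccc2C1=O`, differs from compound 2 by propyl in place of hydrogen on a saturated chain carbon, eight bonds along the chain from a carbonyl carbon. Within the data shown here, the only measured step bears on this change indirectly: it exchanged a branched short chain for a straight long one and moved the number far upward, whereas the present change lengthens an already long straight chain at its far end. Among the measured compounds shown here, no step of that shape has been measured, so its size is unknown; the one known step gives no sign that a longer chain lowers the number, and a modest further rise or no step beyond the scatter is expected, amounting to a 1.7-fold higher number from compound 2 to compound 3 (0.22 log units; within the scatter). Compound 3 is accordingly estimated at 250000 nM, within a range from 40000 nM to 1500000 nM.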

Compound 3, half-maximal inhibitory concentration: 249000 nM
Estimate against measurement, compound 3: 1.0-fold (0.00 log units) above, within the range that was stated.
By their numbers in this assay, from the lowest: compound 1; then compounds 2 and 3 (each within the scatter of the next).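

In this assay, propyl in place of hydrogen on a saturated chain carbon, eight bonds along the chain from a carbonyl carbon, amounts to a 1.7-fold higher number from compound 2 to compound 3 (0.22 log units; within the scatter), so this change does not separate the two compounds. Among these compounds, this is the first measured change at this position, and it stands in contrast to the one earlier step, a 1300-fold higher number from compound 1 to compound 2 (3.10 log units; beyond the scatter), where octyl took the place of 1-methylbutyl on a carbonyl carbon: the large step seen there has no counterpart here. Nothing measured alongside these numbers speaks to why the two steps differ in size.

The compounds shown leave open whether the large step belongs to the length of the chain or to its methyl branch, since a straight butyl or a branched octyl on the carbonyl carbon would be needed to tell these apart. They also leave open whether a group of another kind on that saturated chain carbon, such as a carboxylic acid or an amine, would move the number in this assay where propyl does not.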